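A Fluoro Substituent and Tolerance in Liver Cells

The compounds below may be only part of what the source reports. "The series", "measured", "known", "first", "only" and "open" are said of these compounds alone.

Three compounds sharing one core were tested in an ADME assay on HepG2 cells (Homo sapiens) for cytotoxicity, read by MTT assay, with a stated time of 24 h; a higher number here means that more compound is tolerated, a lower number that less compound is tolerated. Compound 1 `CC(C)(C)c1ccc(N2CCN(Cc3ccc([N+](=O)[O-])o3)CC2)cc1` gives > 63000 nM, which is a limit of the assay rather than a number. Compound 2 `N#Cc1cccc(N2CCN(Cc3ccc([N+](=O)[O-])o3)CC2)c1` gives > 64000 nM, again a limit. Compound 3 `O=[N+]([O-])c1ccc(CN2CCN(S(=O)(=O)c3ccccc3)CC2)o1` gives > 56000 nM, also a limit. Compound 3 thus stands at the limit of > 56000 nM in this assay, at which 1 of the 3 values shown sits, while the two companions sit at the limit of > 63000 nM in this assay, at which 1 of the 3 values shown sits, and (the limit of > 64000 nM in this assay, at which 1 of the 3 values shown sits). Going by the values given here, all three results say only that the cells tolerate each compound up to the highest amount that was tested, and no compound can be set above or below another on these numbers.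

Compound 4 `O=[N+]([O-])c1ccc(CN2CCN(S(=O)(=O)c3ccc(F)cc3)CC2)o1` is not yet measured in this assay. It differs from compound 3 in a single place: fluoro in place of hydrogen on an aromatic carbon. Among the compounds with values here, no pair of measured compounds differs by one change, so there is no measured step to lean on, and the three values give no hint of any loss of tolerance across the series. The expected step that the limit leaves unreadable from compound 3 to compound 4 is none beyond the usual scatter. Compound 4 is therefore estimated at 60000 nM, with a range from 30000 nM to 120000 nM, and the result is expected once more to be reported only as a limit.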

Compound 4, half-maximal cytotoxic concentration: > 54000 nM
Compound 4 ended at the assay's limit (the forecaster's own chance of this, stated with the estimate: 85%); the middle value is on the limit's open side.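

Compound 3 and compound 4 both ended at limits of the assay rather than at numbers, so no step can be read for fluoro in place of hydrogen on an aromatic carbon. The compounds shown leave open at what concentration any of them would become toxic to the cells in this assay, and whether the fluoro substituent would alter that concentration.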